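This account rests on a few compounds, and the source may have more. Where it says the series, first, only, none or still open, it means among the compounds named here.

Measured compounds:
compound 1, `CC(C)c1ccc(-c2nc(SCc3cn(CC(=O)NC(=O)Nc4ccccn4)nn3)nc(Nc3ccccc3Cl)c2C#N)cc1`: 6790 nM
compound 2, `CC(C)c1ccc(-c2nc(SCc3cn(CC(=O)NC(=O)Nc4ccccn4)nn3)nc(Nc3ccc(F)cc3)c2C#N)cc1`: 7250 nM
compound 3, `CC(C)c1ccc(-c2nc(SCc3cn(CC(=O)NC(=O)Nc4ccccn4)nn3)nc(Nc3cccc(Cl)c3)c2C#N)cc1`: 1130 nM

In a functional assay on B16-F10 cells (Mus musculus) for inhibition, read by MTT assay, with a stated time of 72 h (on this read-out higher numbers stand for weaker inhibition and lower numbers for stronger inhibition), compound 1 gives 6790 nM, the second highest of the three numbers. Compound 2 gives 7250 nM, and a 1.1-fold higher number from compound 1 to compound 2 (0.03 log units; within the scatter). Compound 3 gives 1130 nM, and a 6.0-fold lower number from compound 1 to compound 3 (0.78 log units; beyond the scatter), with a 6.4-fold lower number from compound 2 to compound 3 (0.81 log units; beyond the scatter) pointing the same way.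

Compound 4 is `CC(C)c1ccc(-c2nc(SCc3cn(CC(=O)NC(=O)Nc4ccccn4)nn3)nc(Nc3cccc([N+](=O)[O-])c3)c2C#N)cc1`. It differs from compound 1 in one place: 3-nitrophenyl in place of 2-chlorophenyl on a nitrogen on an aromatic ring. The measured steps that bear on this are the two that lead to compound 3, where a 3-chlorophenyl on the same nitrogen brought a modest move to a lower number, beyond the scatter, from either compound 1 or compound 2. Going by the values given here, no measured pair shows a nitro group on that phenyl, so the size of the step for compound 4 is uncertain. Compound 4 is expected to show a 2.7-fold lower number from compound 1 to compound 4 (0.43 log units; beyond the scatter), in the same direction as the step to compound 3 but with less confidence, because a 6.0-fold lower number from compound 1 to compound 3 (0.78 log units; beyond the scatter) was observed with chlorine rather than a nitro group. For compound 4 the estimate is 2500 nM, with a range from 800 nM to 8000 nM.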

Compound 4, half-maximal inhibitory concentration: 26400 nM
Compound 4: middle estimate off by 11-fold (1.02 log units), on the low side; measured number outside the range, above it.
By their numbers in this assay, from the lowest: compound 3; then compounds 1 and 2 (each within the scatter of the next); then compound 4.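

Read across the ring substituent alone, the result shows that the chloro of compound 3 cannot be swapped freely at this aromatic carbon: in this assay, nitro in place of chloro gives a 23-fold higher number from compound 3 to compound 4 (1.37 log units; beyond the scatter), a large step and wider than any seen among the earlier compounds. Compound 4 also has the highest number of the set, with a 3.9-fold higher number from compound 1 to compound 4 (0.59 log units; beyond the scatter) and a 3.6-fold higher number from compound 2 to compound 4 (0.56 log units; beyond the scatter), so changing the group on the phenyl attached to this nitrogen can move the number either way from compounds 1 and 2: the 3-chlorophenyl of compound 3 lowers it, while the 3-nitrophenyl raises it. No measurement among these compounds offers an explanation for the difference between chloro and nitro.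

With only one chloro and one nitro compound carrying a group at this aromatic carbon, the compounds shown leave open whether the low number of compound 3 is particular to chloro or is shared by other small groups, such as a bromo or a methyl. They also leave open where an amino or a methoxy group in that same place would fall relative to compound 3 and compound 4.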